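The source may report more compounds than this note shows. Statements on the series, on what has been measured and on what is new or still open speak of the compounds shown alone.

Measured compounds:
compound 1, `Fc1ccc(-c2noc3c2CCNCC3)cc1`: in an assay on cells for displacement of a labelled ligand from 5-hydroxytryptamine receptor 6 (Homo sapiens), read by scintillation counting, with a stated time of 1.5 h (a higher number here means a weaker inhibitor, a lower number a stronger inhibitor), compound 1 gives > 10000 nM, which is a limit of the assay and not a number.
compound 2, `Cc1ccc(-c2n[nH]c3c2CCNCC3)cc1`: in this assay compound 2 gives 109 nM.

Among the measured compounds shown here, compound 2 therefore stands as the only numerical value in this assay; the other entry sits at the limit of > 10000 nM in this assay, at which 1 of the 2 values shown sits. Compound 3, `Fc1ccc(-c2n[nH]c3c2CCNCC3)cc1`, is not yet measured. It differs from compound 2 by fluoro in place of methyl on an aromatic carbon. For the measured compounds named here, no measured pair isolates this change, so only a modest step is expected, leaning toward weaker binding, possibly none beyond the scatter. For compound 3 the expected step is a 2.3-fold higher number from compound 2 to compound 3 (0.36 log units; beyond the scatter). The estimate for compound 3 is 250 nM, within 80 nM to 800 nM.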

Compound 3, inhibition constant: 416 nM
Beside the measured number, compound 3's estimate is 1.7-fold (0.22 log units) below it; measured number inside the range.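

In this assay, among the compounds shown here, the first pair that isolates the group para to a large group shows that this position responds to a one-atom exchange: fluoro in place of methyl gives a 3.8-fold higher number from compound 2 to compound 3 (0.58 log units; beyond the scatter). Compound 3 carries the same fluoro group as compound 1, whose > 10000 nM is a limit and not a number. Nothing measured here gives a cause for this step.

A single pair cannot show how other groups at this position would rank. Chloro, methoxy, or an amine there remain open.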